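Solubility notes: compound 3 to compound 4

The compounds below may be only part of what the source reports. "The series", "measured", "known", "first", "only" and "open" are said of these compounds alone.

In a physicochemical assay for solubility, with a stated time of 18 h, at pH 7.4 (a higher number here means a more soluble compound, a lower number a less soluble compound), compound 3 `COc1ccc(-c2ccc3c(NCCCNCc4ccco4)ccnc3c2)cc1` gives 32000 nM, the highest of the three numbers available. Compound 1 `COc1ccc(Oc2ccc3c(NCCCNCc4cc(F)ccc4OC)ccnc3c2)cc1` gives 14500 nM and compound 2 `COc1ccc(F)cc1CNCCCNc1ccnc2cc(Oc3ccc(F)cc3)ccc12` gives 14500 nM in this assay, each beyond the scatter below compound 3. For the measured compounds named here, the one measured step, no change at the digits printed from compound 1 to compound 2 (within the scatter), is within the scatter and concerns a different change. Compound 4 `COc1ccc(-c2ccc3c(NCCCNCc4cc(F)ccc4OC)ccnc3c2)cc1` carries 5-fluoro-2-methoxyphenyl in place of furan-2-yl on a saturated chain carbon bound to an amine nitrogen. Going by the values given here, no measured step covers this exchange. Compound 1 carries the same benzyl group on a different core and gives 14500 nM; compound 3 gives 32000 nM. A modest decrease is therefore expected, a 1.8-fold lower number from compound 3 to compound 4 (0.25 log units; within the scatter). Compound 4 is estimated at 18000 nM in this assay, within 8000 nM to 40000 nM.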

Compound 4, solubility: 32000 nM
Compound 4: middle estimate off by 1.8-fold (0.25 log units), on the low side, within the range that was stated.
By their numbers in this assay, from the lowest: compounds 1 and 2 (each within the scatter of the next); then compounds 3 and 4 (each within the scatter of the next).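

In this assay, 5-fluoro-2-methoxyphenyl in place of furan-2-yl on a saturated chain carbon bound to an amine nitrogen gives no change at the digits printed from compound 3 to compound 4 (within the scatter), so this position tolerates the exchange on the core of compound 4. With that benzyl group held, the aromatic-carbon change does register: 4-methoxyphenyl in place of 4-fluorophenoxy gives a 2.2-fold higher number from compound 2 to compound 4 (0.34 log units; beyond the scatter), and 4-methoxyphenyl in place of 4-methoxyphenoxy gives a 2.2-fold higher number from compound 1 to compound 4 (0.34 log units; beyond the scatter). Nothing available accounts for these numbers.

From the compounds shown here alone, whether a carboxylic acid or a morpholine at the furan-2-yl place would hold the number stays open, as does the outcome with a longer chain.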